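Swapping the aryl group on the hydrazone carbon: compound 3

The source may hold more compounds than are shown below. What is called first, only, known or untested is meant among the compounds shown, and "the series" means these compounds.

Measured so far in an ADME assay on THP-1 cells (Homo sapiens) for cytotoxicity; a lower number here means a stronger inhibitor, a higher number a weaker inhibitor: compound 1 `COc1ccccc1-c1nnc(-c2ccc(C(=O)N/N=C/c3ccc(F)cc3)cc2)o1` gives 427000 nM; compound 2 `COc1ccccc1-c1nnc(-c2ccc(C(=O)N/N=C/c3c(O)cc(O)cc3O)cc2)o1` gives 12400 nM.

Going by the values given here, compound 2 stands at the lowest of the two numbers; the only other compound is compound 1, and the step between them was a 34-fold lower number from compound 1 to compound 2 (1.54 log units; beyond the scatter). Compound 3 `COc1ccccc1-c1nnc(-c2ccc(C(=O)N/N=C/c3cccc([N+](=O)[O-])c3)cc2)o1` is not yet measured. Its change from compound 2 is 3-nitrophenyl in place of 2,4,6-trihydroxyphenyl on a carbon with a double bond to nitrogen. Among the compounds with values here, only the step from compound 1 to compound 2 bears on this, as it concerns the same place; that step was large. Since compound 3, like compound 1, lacks the hydroxyl donors, the number is expected to move back up, with an estimated step of a 16-fold higher number from compound 2 to compound 3 (1.21 log units; beyond the scatter). Compound 3 is estimated at 200000 nM, within 40000 nM to 700000 nM.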

Compound 3, half-maximal inhibitory concentration: 119000 nM
Compound 3: middle estimate off by 1.7-fold (0.23 log units), on the high side; measured number inside the range.
By their numbers in this assay, from the lowest: compound 2; then compound 3; then compound 1.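

At the carbon with a double bond to nitrogen, the number also moves between two aryl groups that carry no hydroxyl: 3-nitrophenyl in place of 4-fluorophenyl gives a 3.6-fold lower number from compound 1 to compound 3 (0.55 log units; beyond the scatter) in this assay. Yet 3-nitrophenyl in place of 2,4,6-trihydroxyphenyl gives a 9.6-fold higher number from compound 2 to compound 3 (0.98 log units; beyond the scatter), so the trihydroxyphenyl compound keeps the lowest number of the three. No supporting measurement explains either step.

The compounds shown leave open whether a single hydroxyl on this ring would give a similar number. They also do not show how an amine or a carboxylic acid on this ring would behave.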